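Swapping 3,5-dimethoxyphenyl for 3,4-dimethoxyphenyl

The compounds below may be only part of what the source reports. "The series", "measured", "known", "first", "only" and "open" are said of these compounds alone.

In an ADME assay on cells (Lymphocyte, Homo sapiens) for cytotoxicity, read by MTT assay, with a stated time of 48 h (a higher number here means a weaker inhibitor, a lower number a stronger inhibitor), compound 1 `COC(=O)/C(=C\c1ccc(OC(=O)c2ccccc2)cc1)Sc1ccnc2cc(Cl)ccc12` reads > 100000 nM, which is a limit of the assay and not a number. Among the measured compounds shown here, compound 2 `COC(=O)/C(=C\c1ccc(OC(=O)c2cc(OC)cc(OC)c2)cc1)Sc1ccnc2cc(Cl)ccc12` gives 84100 nM, the only actual number so far. Compound 3 `COC(=O)/C(=C\c1ccc(OC(=O)c2ccc(OC)c(OC)c2)cc1)Sc1ccnc2cc(Cl)ccc12` keeps the same atoms, joined differently, on a carbonyl carbon: 3,4-dimethoxyphenyl in place of 3,5-dimethoxyphenyl on a carbonyl carbon. For the measured compounds named here, the one measured step at that carbonyl carbon is an at least 1.1-fold lower number from compound 1 to compound 2 (0.07 log units; that floor lies within the scatter). It offers no sign of a large effect there, so no change beyond the scatter is expected, and the estimated step is a 1.1-fold lower number from compound 2 to compound 3 (0.02 log units; within the scatter). For compound 3 the expected value is 80000 nM, with an estimated range of 35000 nM to 100000 nM.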

Compound 3, half-maximal inhibitory concentration: 51100 nM
The estimate for compound 3 lay 1.6-fold (0.19 log units) above the measured number; low and high end bracket the measured number.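

Exchanging 3,5-dimethoxyphenyl for 3,4-dimethoxyphenyl on the carbonyl carbon gives a 1.6-fold lower number from compound 2 to compound 3 (0.22 log units; within the scatter), so in this assay rearranging the same atoms does not separate these two compounds. Against phenyl, the comparison reads an at least 1.9-fold lower number from compound 1 to compound 3 (0.29 log units; that floor lies within the scatter). Compound 1 has a limit and not a number, so that step gives only a floor, and its true size cannot be read: the limit of > 100000 nM in this assay, at which 1 of the 3 values shown sits.

From the compounds shown here alone, whether a different group at this carbonyl carbon, such as an amine or a carboxylic acid on the ring, would give a step beyond the scatter remains open.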